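This account rests on a few compounds, and the source may have more. Where it says the series, first, only, none or still open, it means among the compounds named here.

Compound 1 `O=C(O)CCC/C=C\C[C@H]1[C@H](F)CC[C@@H]1NS(=O)(=O)c1ccccc1` gives 1100 nM in a functional assay on a cell-free system (plasma) for inhibition of thromboxane A2 receptor (Homo sapiens), read by turbidimetry; a lower number here means a stronger inhibitor, a higher number a weaker inhibitor. Compound 3 `O=C(O)CC/C=C\C[C@H]1[C@H](F)CC[C@@H]1NS(=O)(=O)c1ccccc1` differs from it by carboxy in place of carboxymethyl on a saturated chain carbon, two bonds along the chain from a double-bonded chain carbon, and in this assay compound 3 gives 2000 nM, a step of a 1.8-fold higher number from compound 1 to compound 3 (0.26 log units; within the scatter). Compound 2 `O=C(O)CCCCCC[C@@H]1[C@@H](CNS(=O)(=O)c2ccc(F)cc2)CC[C@H]1F` has a different core; the difference between the two cores is not broken down here. In this assay compound 2 gives 6000 nM, the highest of the three numbers. Compound 4 `O=C(O)CCCCC[C@@H]1[C@@H](CNS(=O)(=O)c2ccc(F)cc2)CC[C@H]1F` is the not yet measured partner of compound 2 and differs from it by carboxy in place of carboxymethyl on a saturated chain carbon, five bonds along the chain from a saturated ring carbon. This is the same kind of change as that from compound 1 to compound 3, though the place differs: there it sat two bonds along the chain from a double-bonded chain carbon, here five bonds along the chain from a saturated ring carbon. The expectation for the step rests on a 1.8-fold higher number from compound 1 to compound 3 (0.26 log units; within the scatter). For compound 4 a step of a 1.7-fold higher number from compound 2 to compound 4 (0.22 log units; within the scatter) is expected. Compound 4 is thus estimated at 10000 nM, within 4000 nM to 25000 nM.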

Compound 4, half-maximal inhibitory concentration: 4700 nM
For compound 4 the middle estimate is 2.1-fold (0.33 log units) above the measured one; the measured number falls inside the stated range.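

Carboxy in place of carboxymethyl gave a 1.3-fold lower number from compound 2 to compound 4 (0.11 log units; within the scatter) in this assay, so on this core the change leaves the number within the scatter. Set beside the earlier step, the change reads alike on the two cores: the same change on two cores in this assay, a 1.8-fold higher number (0.26 log units; within the scatter) from compound 1 to compound 3 and a 1.3-fold lower number (0.11 log units; within the scatter) from compound 2 to compound 4, 2.3-fold (0.37 log units) apart, within the scatter of two such steps. Going by these compounds alone, this shows that the change gave no step beyond the scatter on either core, but with only two pairs it does not show a fixed size or direction for the step, nor that it would hold on any other core.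

The compounds shown leave open how an amide or a tetrazole in place of the carboxylic acid would read in this assay. They also leave open whether a longer chain would stay within the scatter.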